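Aromatic group change from compound 2 to compound 3

The source may report more compounds than this note shows. Statements on the series, on what has been measured and on what is new or still open speak of the compounds shown alone.

In a physicochemical assay for lipophilicity (a lower number here means a more polar compound, a higher number a more lipophilic compound), two compounds on the shared core have been measured so far. Compound 1 `C[C@H]1CC[C@@H]2[C@@H](OC(=O)[C@]23CC(c2ccccc2[N+](=O)[O-])=NO3)[C@]2(C)C(=O)C=C[C@@]12O` gives 1.37, and compound 2 `COc1ccc(C2=NO[C@]3(C2)C(=O)O[C@@H]2[C@H]3CC[C@H](C)[C@]3(O)C=CC(=O)[C@@]23C)cc1OC` gives 1.06, the lower of the two numbers.

The next compound is compound 3 `C[C@H]1CC[C@@H]2[C@@H](OC(=O)[C@]23CC(c2ccccc2F)=NO3)[C@]2(C)C(=O)C=C[C@@]12O`, which differs from compound 2 in one place: 2-fluorophenyl in place of 3,4-dimethoxyphenyl on a carbon with a double bond to nitrogen. This puts 2-fluorophenyl in place of 3,4-dimethoxyphenyl on a carbon with a double bond to nitrogen.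

For the measured compounds named here, only one measured step bears on this change, and it involves the same place: a number 0.31 log units lower from compound 1 to compound 2 (beyond the scatter). Going by the values given here, no measured compound carries 2-fluorophenyl, so that single step is a loose guide to size. As compound 2 at 1.06 is the lower of the two, a step up in this assay is expected on leaving 3,4-dimethoxyphenyl, of similar or somewhat larger size than a number 0.31 log units lower from compound 1 to compound 2 (beyond the scatter). The expected change is a number 0.39 log units higher from compound 2 to compound 3 (beyond the scatter). For compound 3 the estimated value is 1.45, with an expected range of 1.1 to 1.8.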

Compound 3, partition coefficient: 1.58
The estimate for compound 3 lay 0.13 log units below the measured number, and the stated range covers the measured number.
By their numbers in this assay, from the lowest: compound 2; then compounds 1 and 3 (each within the scatter of the next).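

In this assay, the position on the carbon with a double bond to nitrogen now gives a second step beyond the scatter: 2-fluorophenyl in place of 3,4-dimethoxyphenyl gives a number 0.52 log units higher from compound 2 to compound 3 (beyond the scatter) and confirms that the low value of compound 2 is not peculiar to a comparison with the 2-nitrophenyl group. Fluoro in place of nitro on the aromatic carbon gives a number 0.21 log units higher from compound 1 to compound 3 (within the scatter) and so does not separate the 2-fluorophenyl and 2-nitrophenyl groups in this assay, leaving compound 2 alone at the low end of the three. No measurement at hand accounts for these steps.

Still open, from the compounds shown here alone, is whether the separation of compound 2 follows from the presence of two methoxy groups or from where they sit on the aromatic ring, a question that a phenyl ring carrying a single methoxy group could address. Also open, going by these compounds, is where a plain phenyl group, or a phenyl ring bearing a carboxylic acid or a dimethylamino group, would fall on the shared core relative to these three compounds.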